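This account rests on a few compounds, and the source may have more. Where it says the series, first, only, none or still open, it means among the compounds named here.

Measured so far in a functional assay on HCT-116 cells (Homo sapiens) for inhibition, read by MTT assay, with a stated time of 48 h (a lower number here means a stronger inhibitor, a higher number a weaker inhibitor), are two compounds.

- compound 1 `COc1ccc(CN(C(C)=O)c2cc(OC)c(OC)c(OC)c2)cc1O` gives 270 nM
- compound 2 `CCC/C=C/C(=O)N(Cc1ccc(OC)c(O)c1)c1cc(OC)c(OC)c(OC)c1` gives 95 nM

Of these two, compound 2 has the lower number, 95 nM, which makes it the stronger inhibitor. The next compound, compound 3 `COc1ccc(CN(C(=O)CCl)c2cc(OC)c(OC)c(OC)c2)cc1O`, alters a single group of compound 2, and the rest of the structure stays the same: chloromethyl in place of pent-1-en-1-yl on a carbonyl carbon.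

For the measured compounds named here, only one measured step bears on this change, and it sits on the same carbonyl carbon: a 2.8-fold lower number from compound 1 to compound 2 (0.45 log units; beyond the scatter), with pent-1-en-1-yl in place of methyl. Chloromethyl is closer to that methyl than to the longer chain, so some of that modest gain may be lost. The two measured compounds show nothing about the effect of the chlorine itself, which leaves the expectation uncertain. A rise in the number is expected, but a smaller one than the measured step, and the estimated change is a 1.8-fold higher number from compound 2 to compound 3 (0.25 log units; within the scatter). For compound 3 the expected value is 170 nM, with an estimated range from 50 nM to 600 nM.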

Compound 3, half-maximal inhibitory concentration: 250 nM
Beside the measured number, compound 3's estimate is 1.5-fold (0.17 log units) below it, and the stated range covers the measured number.
By their numbers in this assay, from the lowest: compound 2; then compounds 3 and 1 (each within the scatter of the next).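

In this assay, putting chloromethyl in place of pent-1-en-1-yl on the carbonyl carbon costs strength, with a 2.6-fold higher number from compound 2 to compound 3 (0.42 log units; beyond the scatter), so the longer chain is worth keeping at this position. Chloro in place of hydrogen on the saturated chain carbon bound to the carbonyl carbon makes no readable difference, with a 1.1-fold lower number from compound 1 to compound 3 (0.03 log units; within the scatter), which leaves compound 2 as the only one of the three whose steps to both others lie beyond the scatter. No measurement shown here accounts for these differences.

The compounds shown do not separate the length of the pent-1-en-1-yl chain from its double bond, and a saturated pentyl chain or a shorter propenyl chain on the same carbonyl carbon would be needed to tell these two features apart. From the compounds shown here alone, it also stays open whether the lack of a readable chloro effect holds for other groups on that saturated chain carbon, such as a bromine, a hydroxyl or an amine, or whether it holds only for chlorine.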